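Indazolyl-phenyl ureas: the unsubstituted indazole

The source may hold more compounds than are shown below. What is called first, only, known or untested is meant among the compounds shown, and "the series" means these compounds.

Measured compounds:
- Compound 1 `O=C(Nc1ccc(-n2ncc3c(C(F)(F)F)cccc32)cc1)Nc1ccc(Cl)c(C(F)(F)F)c1`: 3000 nM
- Compound 2 `O=C(Nc1ccc(-n2ncc3c(F)cccc32)cc1)Nc1ccc(Cl)c(C(F)(F)F)c1`: 9800 nM
- Compound 3 `Cc1cccc2c1cnn2-c1ccc(NC(=O)Nc2ccc(Cl)c(C(F)(F)F)c2)cc1`: 3900 nM

All three were tested in a functional assay on LoVo cells (Homo sapiens) for cytotoxicity, read by MTT assay, with a stated time of 72 h; on this read-out higher numbers stand for weaker inhibition and lower numbers for stronger inhibition. Compound 3 stands second highest of the three numbers; its nearest neighbour is compound 1, which differs by a 1.3-fold higher number from compound 1 to compound 3 (0.11 log units; within the scatter), while compound 2 sits further off, with a 2.5-fold lower number from compound 2 to compound 3 (0.40 log units; beyond the scatter).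

Compound 4 `O=C(Nc1ccc(-n2ncc3ccccc32)cc1)Nc1ccc(Cl)c(C(F)(F)F)c1` is the next member. The change from compound 3 reads (hydrogen in place of methyl on an aromatic carbon), in words: hydrogen in place of methyl on an aromatic carbon.

For the measured compounds named here, two measured steps bear on this position. Swapping trifluoromethyl for methyl gave a 1.3-fold higher number from compound 1 to compound 3 (0.11 log units; within the scatter), a move within the scatter. Swapping fluoro for methyl gave a 2.5-fold lower number from compound 2 to compound 3 (0.40 log units; beyond the scatter), a modest gain. The smallest group examined so far, fluoro, gave the weakest compound, and removing the methyl altogether takes the position one step smaller still. The expectation is therefore a modest rise in this assay for compound 4, of about a 2.1-fold higher number from compound 3 to compound 4 (0.31 log units; beyond the scatter), landing near compound 2 rather than compound 1. Going by the values given here, compound 4 is estimated at 8000 nM, with a range of 3500 nM to 18000 nM; no steps are available to fix this more tightly.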

Compound 4, half-maximal inhibitory concentration: 8700 nM
Beside the measured number, compound 4's estimate is 1.1-fold (0.04 log units) below it, and the stated range covers the measured number.
By their numbers in this assay, from the lowest: compounds 1 and 3 (each within the scatter of the next); then compounds 4 and 2 (each within the scatter of the next).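

In this assay, the unsubstituted position groups with the fluoro compound and not with the two carbon-bearing groups: a 1.1-fold lower number from compound 2 to compound 4 (0.05 log units; within the scatter), a gap within the scatter, whereas a 2.2-fold higher number from compound 3 to compound 4 (0.35 log units; beyond the scatter) and a 2.9-fold higher number from compound 1 to compound 4 (0.46 log units; beyond the scatter) are both modest losses beyond the scatter. This gives the series a hydrogen baseline that it lacked, and against that baseline fluoro shows no separable effect, while methyl in compound 3 and trifluoromethyl in compound 1 each carry a modest gain, so the weak fluoro result reflects the absence of a gain and not a penalty specific to fluoro. No measurement among the data shown accounts for this split between the substituents.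

From the compounds shown here alone, with only methyl and trifluoromethyl giving a gain over hydrogen, it remains open whether a carbon attached at this position is what matters, and a methoxy group, an amine or chlorine would test that. Going by these compounds, whether a longer chain such as ethyl or propyl would extend the gain, hold it or lose it also remains open, as does whether the same order would hold at the other ring positions of the shared core.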